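Replacing phenylcarbamoyl with 3,3-dimethylbutyl on the ring amine

The source may hold more compounds than are shown below. What is called first, only, known or untested is meant among the compounds shown, and "the series" means these compounds.

In a physicochemical assay for solubility (a higher number here means a more soluble compound, a lower number a less soluble compound), compound 1 (`O=C(CN1CCNCC1)N1CCC(NS(=O)(=O)c2cc(S(=O)(=O)c3ccccc3)ccc2C(F)(F)F)CC1`) gives 50000 nM and compound 2 (`O=C([C@@H]1CCCN1C(=O)Nc1ccccc1)N1CCC(NS(=O)(=O)c2cc(S(=O)(=O)c3ccccc3)ccc2C(F)(F)F)CC1`) gives 25000 nM within the scatter of compound 1, so no order can be read between the two numbers available. Compound 3 (`CC(C)(C)CCN1CCC[C@H]1C(=O)N1CCC(NS(=O)(=O)c2cc(S(=O)(=O)c3ccccc3)ccc2C(F)(F)F)CC1`) has 3,3-dimethylbutyl in place of phenylcarbamoyl on an amine nitrogen in a ring. Within the data shown here, no measured step covers this change. In this assay the expected step is small (a 1.3-fold lower number from compound 2 to compound 3 (0.10 log units; within the scatter)). The only anchor for it is compound 2 at 25000 nM in the measured data. In this assay the estimate for compound 3 is 20000 nM with an expected range from 5000 nM to 60000 nM across repeat measurements.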

Compound 3, solubility: 12500 nM
Compound 3: the middle estimate sits 1.6-fold (0.20 log units) above what was measured; measured number inside the range.
By their numbers in this assay, from the lowest: compounds 3, 2 and 1 (each within the scatter of the next, the first and the last beyond it).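

In this assay the change on the amine nitrogen in a ring gives a 2.0-fold lower number from compound 2 to compound 3 (0.30 log units; within the scatter) and so leaves no readable difference between 3,3-dimethylbutyl, which has no ring and no hydrogen-bond donor, and phenylcarbamoyl at this position. With 1-(3,3-dimethylbutyl)pyrrolidin-2-yl in place of (piperazin-1-yl)methyl on a carbonyl carbon, the series shows a 4.0-fold lower number from compound 1 to compound 3 (0.60 log units; beyond the scatter) as its first step beyond the scatter, a modest one. No evidence bears on the cause of either step.

Open, going by these compounds, is whether a carboxylic acid or a primary amine on this ring nitrogen would move the number in this assay beyond the scatter of compound 2. Also open, on these data alone, is whether a longer chain than 3,3-dimethylbutyl would do so.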